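The compounds below may be only part of what the source reports. "The series", "measured", "known", "first", "only" and "open" are said of these compounds alone.

Measured compounds:
compound 1 `O=C(Cc1csc2nc(-c3ccc(Br)cc3)cn12)N/N=C/c1ccccc1O` — 3890 nM
compound 2 `O=C(Cc1csc2nc(-c3ccc(Br)cc3)cn12)N/N=C/c1ccc(O)cc1` — 18200 nM
compound 3 `COc1cccc(OC)c1/C=N/NC(=O)Cc1csc2nc(-c3ccc(Br)cc3)cn12` — 13200 nM

All three numbers come from a functional assay on HOP-62 cells (Homo sapiens) for inhibition, read by sulforhodamine B assay, with a stated time of 48 h; a higher number here means a weaker inhibitor of growth, a lower number a stronger inhibitor of growth. Compound 1 gives the lowest number of the three; compound 3 is nearest, compound 2 furthest.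

Compound 4 `O=C(Cc1csc2nc(-c3ccc(Br)cc3)cn12)N/N=C/c1ccc(Cl)cc1Cl` is unmeasured. Change from compound 1: 2,4-dichlorophenyl in place of 2-hydroxyphenyl on a carbon with a double bond to nitrogen

Two measured steps start from the same 2-hydroxyphenyl of compound 1 and bear on this: a 4.7-fold higher number from compound 1 to compound 2 (0.67 log units; beyond the scatter) and a 3.4-fold higher number from compound 1 to compound 3 (0.53 log units; beyond the scatter). Both replacements gave a modest rise. For 2,4-dichlorophenyl a rise of similar size in this assay is therefore expected, so a 2.6-fold higher number from compound 1 to compound 4 (0.41 log units; beyond the scatter) is the estimated step. Compound 4 is estimated at 10000 nM, expected range 4000 nM to 30000 nM.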

Compound 4, concentration for 50% growth inhibition: 16600 nM
The estimate for compound 4 lay 1.7-fold (0.22 log units) below the measured number; the range from low to high includes it.
By their numbers in this assay, from the lowest: compound 1; then compounds 3, 4 and 2 (each within the scatter of the next).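

In this assay, 2,4-dichlorophenyl on the carbon with a double bond to nitrogen also raises the number (a 4.3-fold higher number from compound 1 to compound 4 (0.63 log units; beyond the scatter)), so a replacement with chlorine and no oxygen does not recover the result of 2-hydroxyphenyl. It sits within the scatter of both earlier replacements (a 1.3-fold higher number from compound 3 to compound 4 (0.10 log units; within the scatter)) (a 1.1-fold lower number from compound 2 to compound 4 (0.04 log units; within the scatter)), which leaves compound 1 alone apart from three differently substituted rings. No measurement at hand accounts for this. Still open, from the compounds shown here alone, is whether the low number of compound 1 is specific to the hydroxyl, or would hold for 2-aminophenyl or 2-methoxyphenyl at this position.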